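The compounds below may be only part of what the source reports. "The series", "measured", "known", "first", "only" and "open" are said of these compounds alone.

Measured in an ADME assay on Raji cells (Homo sapiens) for cytotoxicity, with a stated time of 72 h; a lower number here means that less compound is needed, a higher number that more compound is needed for the effect:
- Compound 1 `O=C(Nc1cccc(-c2ccccc2)c1)c1cc([N+](=O)[O-])ccc1Cl`: > 27000 nM, a limit
- Compound 2 `O=C(Nc1cccc(-c2nc3ccccc3o2)c1)c1cc([N+](=O)[O-])ccc1Cl`: > 25000 nM, a limit

In this assay compound 2 gives > 25000 nM. That figure is a limit of the assay and not a number. The effect was not reached as a measured value, so compound 2 has no exact position on this scale.

Compound 3 `O=C(Nc1cc(-c2nc3ccccc3o2)ccc1F)c1cc([N+](=O)[O-])ccc1Cl` differs from compound 2 by one small change: fluoro in place of hydrogen on an aromatic carbon. This carbon is ortho to a large group and para to a 1,3-benzoxazol-2-yl group.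

Within the data shown here, only one measured step bears on this change, a step that the two limits leave unreadable from compound 1 to compound 2. It involves a different group and has no readable size, so it offers no size to carry over. With compound 2 as the only anchor, no step beyond the usual scatter is expected, and another limit would be the likeliest result.

The expected change is a number no higher from compound 2 to compound 3 (the limit leaves the size open). For compound 3 the estimated value is 25000 nM, with an expected range from 10000 nM to 60000 nM.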

Compound 3, half-maximal effective concentration: > 25000 nM
Compound 3 ended at the assay's limit; the forecaster's own chance of this, stated with the estimate: 80%; the middle value sits exactly at the limit.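

In this assay compound 3 gives > 25000 nM, which is a limit of the assay and not a number. Compound 2 also stands at a limit, and no step can be read from compound 2 to compound 3. The compounds shown leave open whether fluoro in place of hydrogen changes the half-maximal effective concentration in this assay at all.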